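Methylcarbamoyl in Place of Pyridinyl on the Sulfonamide Core

The compounds below may be only part of what the source reports. "The series", "measured", "known", "first", "only" and "open" are said of these compounds alone.

Measured compounds:
Compound 1, `COc1ccc(C(F)(F)F)cc1S(=O)(=O)Nc1cccnc1`, gives 3010 nM in an assay on isolated protein for inhibition of alkaline phosphatase, tissue-nonspecific isozyme (Homo sapiens); on this read-out lower numbers stand for stronger inhibition and higher numbers for weaker inhibition.
Compound 2, `COc1ccc(Cl)cc1S(=O)(=O)Nc1cncc(-c2cccnc2)c1`, gives "not determined" (no result reported) in this assay, so it has no result there.

Compound 2 stands without a number, so the step to compound 3 starts from no measured value. Compound 3 is `CNC(=O)c1cncc(NS(=O)(=O)c2cc(Cl)ccc2OC)c1`, and it differs from compound 2 by methylcarbamoyl in place of pyridin-3-yl on an aromatic carbon. Within the data shown here, with no measured pair to lean on, the account expects no shift beyond the scatter in this assay in either direction. Among the measured compounds shown here, the only anchor is compound 1 at 3010 nM. Compound 3 is therefore estimated at 3000 nM, within a range from 600 nM to 15000 nM.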

Compound 3, half-maximal inhibitory concentration: > 20000 nM
Compound 3: only a limit was reported; the forecaster's own chance of this, stated with the estimate: 15%; middle value at least 6.6-fold (0.82 log units) from the limit.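

No step can be read from compound 2 to compound 3: compound 2 has no result, and compound 3 gives only a limit, > 20000 nM. Going by these compounds, whether methylcarbamoyl in place of pyridin-3-yl shifts inhibition in this assay stays open.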